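The compounds below may be only part of what the source reports. "The series", "measured", "known", "first", "only" and "open" are said of these compounds alone.

Values measured in a functional assay on the whole organism with Mus musculus as the target, in the maximal electroshock model (on this read-out higher numbers stand for an effect only at larger amounts of compound and lower numbers for an effect already at smaller amounts), for the three compounds:
- compound 1 `OC1CCN(c2ccc(-c3ccccc3)nn2)CC1` gives 86 mg/kg
- compound 2 `OC1CCN(c2ccc(-c3ccc(Cl)cc3)nn2)CC1` gives 29 mg/kg
- compound 3 `OC1CCN(c2ccc(-c3ccc(F)cc3)nn2)CC1` gives 48 mg/kg

Compound 2 stands within the scatter of compound 3 (a 1.7-fold higher number from compound 2 to compound 3 (0.22 log units; within the scatter)) and beyond the scatter from compound 1 (a 3.0-fold lower number from compound 1 to compound 2 (0.47 log units; beyond the scatter)). Compound 4 `Cc1cc(Cl)ccc1-c1ccc(N2CCC(O)CC2)nn1` departs from compound 2 by one change (methyl in place of hydrogen on an aromatic carbon), methyl in place of hydrogen on an aromatic carbon.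

Going by the values given here, no measured compound carries a methyl group. The nearest guides are the modest chloro step (a 3.0-fold lower number from compound 1 to compound 2 (0.47 log units; beyond the scatter)) and the fluoro step (a 1.8-fold lower number from compound 1 to compound 3 (0.25 log units; within the scatter)), which stays within the scatter. In this assay no clear shift in either direction is therefore expected (estimated: a 1.1-fold lower number from compound 2 to compound 4 (0.05 log units; within the scatter)). The value expected for compound 4 is 26 mg/kg (estimated range 11 mg/kg to 62 mg/kg).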

Compound 4, dose for half-maximal effect: 10 mg/kg
Estimate against measurement, compound 4: 2.6-fold (0.41 log units) above; the whole stated range lies above it.
By their numbers in this assay, from the lowest: compound 4; then compounds 2, 3 and 1 (each within the scatter of the next, the first and the last beyond it).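

In this assay, methyl in place of hydrogen on the aromatic carbon ortho to a large group and meta to the chloro group gives a 2.9-fold lower number from compound 2 to compound 4 (0.46 log units; beyond the scatter), a modest step beyond the scatter. The earlier compounds shown here varied only a single halogen, whereas this result shows that a small carbon group added to the chloro-bearing ring can also lower the number. No measurement here accounts for this step.

From the compounds shown here alone, whether a methoxy group or an ethyl group on the same carbon would give a similar step remains open. So does whether methyl has this effect without the chloro group.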